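A few compounds are considered here, and "the series" means these few. Any claim that something is new, unique, unknown or untested is made for them only; others in the source may bear on it.

Among the measured compounds shown here, in a functional assay on MDA-MB-231 cells (Homo sapiens) for inhibition, read by sulforhodamine B assay, with a stated time of 48 h (a lower number here means a stronger inhibitor of growth, a higher number a weaker inhibitor of growth), compound 2 (`c1ccc(-c2nc3ncccn3c2CN2CCCC2)cc1`) gives 70 nM, the lower of the two numbers so far. Compound 1 (`Cc1ccn2c(CN3CCCC3)c(-c3ccc(O)cc3)nc2n1`) gives 1200 nM, a gap well beyond the usual scatter. Compound 3 (`Cc1ccn2c(CN3CCCC3)c(-c3ccccc3)nc2n1`) is compound 2 with one change: methyl in place of hydrogen on an aromatic carbon of the six-membered aromatic ring with 2 nitrogen, (methyl in place of hydrogen on an aromatic carbon). For the measured compounds named here, no comparison of measured compounds isolates this change. Compound 1 at 1200 nM carries the same methyl, but it also differs elsewhere, so its number can only hint at the direction. A modest move toward weaker inhibition is therefore expected, and it may not clear the scatter by much. The estimated change is a 2.1-fold higher number from compound 2 to compound 3 (0.33 log units; beyond the scatter). For compound 3 the expected value is 150 nM, with an estimated range from 40 nM to 550 nM.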

Compound 3, concentration for 50% growth inhibition: 4830 nM
Compound 3: middle estimate off by 32-fold (1.51 log units), on the low side; measured number outside the range, above it.
By their numbers in this assay, from the lowest: compound 2; then compound 1; then compound 3.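

In this assay, adding a single methyl on an aromatic carbon of the six-membered aromatic ring with 2 nitrogen gives a 69-fold higher number from compound 2 to compound 3 (1.84 log units; beyond the scatter), so this small change at this position weakens growth inhibition sharply. Compound 1 could not show this, since it carries the methyl together with a hydroxy on the other ring. Compound 3 now separates the two groups: hydrogen in place of that hydroxy gives a 4.0-fold higher number from compound 1 to compound 3 (0.60 log units; beyond the scatter), so with the methyl present, the hydroxy compound is the stronger inhibitor.

No measurement shown explains why the methyl has so large an effect. Also open, as far as these compounds go, is whether an ethyl group or a chlorine atom at the same position would weaken inhibition as much, and whether a hydroxy would also help without the methyl.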